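The compounds below may be only part of what the source reports. "The series", "measured", "known", "first", "only" and "open" are said of these compounds alone.

Going by the values given here, in a functional assay on HepG2 cells (Homo sapiens) for inhibition, read by MTT assay, with a stated time of 48 h (on this read-out lower numbers stand for stronger inhibition and higher numbers for weaker inhibition), compound 1 (`COc1ccc(N(C)c2nc(C)nc3ccccc23)cc1C(=O)OCC[Se]C#N`) gives 890 nM, the highest of the three numbers measured so far. Compound 3 (`COc1ccc(N(C)c2nc(C)nc3ccccc23)cc1C(=O)NCC[Se]C#N`) gives 179 nM, and compound 2 (`Cc1nc(N(C)c2ccc([Se]C#N)c(C)c2)c2ccccc2n1`) gives 9 nM. Compound 4 (`COc1ccc(N(C)c2nc(C)nc3ccccc23)cc1OCCCC[Se]C#N`) has not yet been measured. Its difference from compound 1 is a group of 8 heavy atoms (5 carbon, 1 nitrogen, 1 oxygen, 1 selenium; no ring) in place of a group of 8 heavy atoms (4 carbon, 1 nitrogen, 2 oxygen, 1 selenium; no ring), on an aromatic carbon, ortho to a methoxy group and meta to a large group.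

Among the compounds with values here, only one measured step touches this side chain: a 5.0-fold lower number from compound 1 to compound 3 (0.70 log units; beyond the scatter). That change sits on a carbonyl carbon, which the entering group in compound 4 does not contain, so it is a loose guide rather than a direct precedent. Within the data shown here, compound 2 differs from compound 1 in more than one place, and no single-change step connects them, so its much lower value sets no size for this change. Among the measured compounds shown here, no measured compound carries the entering group. A modest move to a lower number is therefore expected, on the evidence of a 5.0-fold lower number from compound 1 to compound 3 (0.70 log units; beyond the scatter), with real doubt about its size. The estimated change is a 3.0-fold lower number from compound 1 to compound 4 (0.47 log units; beyond the scatter). For compound 4, the expected value in this assay is 300 nM, with an estimated range from 70 nM to 1300 nM.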

Compound 4, half-maximal inhibitory concentration: 6460 nM
Beside the measured number, compound 4's estimate is 22-fold (1.33 log units) below it; measured number outside the range, above it.
By their numbers in this assay, from the lowest: compound 2; then compound 3; then compound 1; then compound 4.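

In this assay, exchanging the ester side chain for a chain with no carbonyl gives a 7.3-fold higher number from compound 1 to compound 4 (0.86 log units; beyond the scatter), and exchanging the amide side chain for the same chain gives a 36-fold higher number from compound 3 to compound 4 (1.56 log units; beyond the scatter). Until now this side chain had shown only a downward move, a 5.0-fold lower number from compound 1 to compound 3 (0.70 log units; beyond the scatter), so the new result shows that changes here can push the number in either direction, even among groups of 8 heavy atoms that all end in the same selenocyanate. Nothing available accounts for this reversal.

The compounds shown do not separate the loss of the carbonyl from the change in how the chain is built, as the entering group differs from both earlier groups in its attachment to the aromatic carbon and in its carbon count. A shorter or longer chain on the same ether oxygen would test the role of chain length, while a ketone in the chain would test whether a carbonyl alone restores the lower numbers of compound 1 and compound 3.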